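The source may report more compounds than this note shows. Statements on the series, on what has been measured and on what is new or still open speak of the compounds shown alone.

Measured so far in an ADME assay on the whole organism (Rattus norvegicus) for metabolic stability, read by LC-MS, at a dose of 1 mg/kg by the intravenous route; on this read-out lower numbers stand for a shorter-lived compound and higher numbers for a longer-lived compound:
compound 1 `CNC(=O)c1c(-c2ccc(F)cc2)oc2cc(N(Cc3ccc(B(O)O)c(F)c3)S(C)(=O)=O)c(C3CC3)cc12` gives 1 h
compound 2 `CNC(=O)c1c(-c2ccc(F)cc2)oc2cc(N(c3ccc(B(O)O)c(Cl)c3)S(C)(=O)=O)c(C3CC3)cc12` gives 3.7 h

Compound 2 stands highest of the two numbers; the step of a 3.7-fold higher number from compound 1 to compound 2 (0.57 log units; beyond the scatter) sets it beyond the scatter above compound 1. Compound 3 `CNC(=O)c1c(-c2ccc(F)cc2)oc2cc(N(C3CCc4c(B(O)O)cccc43)S(C)(=O)=O)c(C3CC3)cc12` differs from compound 2 in one place: a group of 12 heavy atoms (9 carbon, 1 boron, 2 oxygen; one five-membered non-aromatic ring of carbon only, one six-membered aromatic ring of carbon only) in place of a group of 10 heavy atoms (6 carbon, 1 boron, 2 oxygen, 1 chlorine; one six-membered aromatic ring of carbon only), on a sulfonamide nitrogen. Among the measured compounds shown here, the only measured step, a 3.7-fold higher number from compound 1 to compound 2 (0.57 log units; beyond the scatter), exchanged the group on the sulfonamide nitrogen in a different way, so it bears on this change only loosely, and no measured step removes chlorine or brings in a five-membered non-aromatic ring. For the measured compounds named here, with no closer precedent, no step beyond the scatter is expected in this assay from compound 2 to compound 3, and the estimate is kept near compound 2 with a wide range. Compound 3 is expected to give about 3 h, between 1.2 h and 7 h. The expected step, a 1.2-fold lower number from compound 2 to compound 3 (0.09 log units; within the scatter), lies within the scatter.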

Compound 3, half-life: 1.1 h
The estimate for compound 3 lay 2.7-fold (0.44 log units) above the measured number, and the stated range ends above it.
By their numbers in this assay, from the lowest: compounds 1 and 3 (each within the scatter of the next); then compound 2.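

In this assay, the group on the sulfonamide nitrogen can lower the half-life as well as raise it: a 3.4-fold lower number from compound 2 to compound 3 (0.53 log units; beyond the scatter), with no change in the counts of hydrogen-bond donors and acceptors or in net charge. Set against the fluorine-bearing group of compound 1, the group with the five-membered non-aromatic ring gives a 1.1-fold higher number from compound 1 to compound 3 (0.04 log units; within the scatter), so among these three groups only the chlorine-bearing group of compound 2 stands apart. Nothing on hand accounts for these differences.

The groups of compound 2 and compound 3 differ in several features at once, which leaves open whether the chlorine, the five-membered non-aromatic ring or some other feature tracks with the half-life. Also open, as far as these compounds go, is how an amine or a carboxylic acid on the boron-bearing group would read in this assay.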